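From a Four-Membered Ring to a Three-Membered One

The compounds below may be only part of what the source reports. "The series", "measured", "known", "first", "only" and "open" are said of these compounds alone.

Compound 3 `Fc1ccccc1Cn1cnc2c(N3CCC3)ncnc21` stands apart from its two neighbours. In a functional assay on the whole organism with Rattus norvegicus as the target, in the maximal electroshock model (on this read-out lower numbers stand for an effect already at smaller amounts and higher numbers for an effect only at larger amounts of compound), compound 3 reaches only the assay's limit of > 50 mg/kg, a boundary rather than a measured number (the limit of > 50 mg/kg in this assay, at which 1 of the 3 values shown sits). In this assay compound 1 `Fc1ccccc1Cn1cnc2c(NCC3CC3)ncnc21` gives 4.3 mg/kg and compound 2 `CCN(CC)c1ncnc2c1ncn2Cc1ccccc1F` gives 4.2 mg/kg. The steps of an at least 11-fold higher number from compound 1 to compound 3 (1.06 log units; beyond the scatter) and an at least 11-fold higher number from compound 2 to compound 3 (1.07 log units; beyond the scatter) both show a large loss when the azetidin-1-yl group comes in, whereas a 1.0-fold lower number from compound 1 to compound 2 (0.01 log units; within the scatter) lies within the scatter. Compound 4 `Fc1ccccc1Cn1cnc2c(NC3CC3)ncnc21` differs from compound 3 by cyclopropylamino in place of azetidin-1-yl on an aromatic carbon. Opening that four-membered ring is therefore expected to undo much of the loss, an estimated step of an at least 6.2-fold lower number from compound 3 to compound 4 (0.79 log units; beyond the scatter). Compound 4 is estimated at 8 mg/kg, with a range from 3 mg/kg to 40 mg/kg.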

Compound 4, dose for half-maximal effect: 5 mg/kg
Compound 4: the middle estimate sits 1.6-fold (0.20 log units) above what was measured, within the range that was stated.
By their numbers in this assay, from the lowest: compounds 2, 1 and 4 (each within the scatter of the next). At a limit, above all of these: compound 3.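

Compound 3 alone stays at a limit: the limit of > 50 mg/kg in this assay, at which 1 of the 4 values shown sits.
In this assay, rearranging the same atoms from azetidin-1-yl to cyclopropylamino gives a clear gain (an at least 10-fold lower number from compound 3 to compound 4 (1.00 log units; beyond the scatter)), so the number of heavy atoms in this group does not decide the result. Cyclopropyl on the nitrogen performs within the scatter of cyclopropylmethyl (a 1.2-fold higher number from compound 1 to compound 4 (0.07 log units; within the scatter)), and cyclopropylamino within the scatter of diethylamino (a 1.2-fold higher number from compound 2 to compound 4 (0.08 log units; within the scatter)).

Still open, from the compounds shown here alone, is whether cyclobutylamino on this aromatic carbon behaves like cyclopropylamino, and whether pyrrolidin-1-yl, a five-membered ring, behaves like azetidin-1-yl.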